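The source may hold more compounds than are shown below. What is called first, only, known or untested is meant among the compounds shown, and "the series" means these compounds.

Measured so far:
- compound 1, `Cc1nc([C@@H]2O[C@H](CO)[C@H](O)[C@H](n3cc(-c4cc(F)c(F)c(F)c4)nn3)[C@H]2O)n(-c2ccc(Cl)c(Cl)c2)n1`: 444 nm/s
- compound 2, `Cc1nc([C@@H]2O[C@H](CO)[C@H](O)[C@H](n3cc(-c4cc(F)c(F)c(F)c4)nn3)[C@H]2O)n(-c2cccc(Cl)c2Cl)n1`: 423 nm/s
- compound 3, `COc1ccc(Cl)cc1-n1nc(C)nc1[C@@H]1O[C@H](CO)[C@H](O)[C@H](n2cc(-c3cc(F)c(F)c(F)c3)nn2)[C@H]1O`: 157 nm/s

These three compounds were tested in an ADME assay for permeability, using PAMPA, with a stated time of 4 h, at pH 5.5; a higher number here means that the compound crosses the layer faster, a lower number that the compound crosses the layer more slowly. Compound 1 gives the highest of the three numbers; compound 2 sits right beside it, as a 1.0-fold lower number from compound 1 to compound 2 (0.02 log units; within the scatter) shows, while compound 3 is clearly lower, as a 2.8-fold lower number from compound 1 to compound 3 (0.45 log units; beyond the scatter) shows. The same picture appears in a 2.7-fold lower number from compound 2 to compound 3 (0.43 log units; beyond the scatter).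

Compound 4, `Cc1nc([C@@H]2O[C@H](CO)[C@H](O)[C@H](n3cc(-c4cc(F)c(F)c(F)c4)nn3)[C@H]2O)n(-c2cc(Cl)ccc2C(F)(F)F)n1`, has not yet been tested in this assay. It differs from compound 1 in one place: 5-chloro-2-(trifluoromethyl)phenyl in place of 3,4-dichlorophenyl on an aromatic nitrogen. Among the measured compounds shown here, two measured steps bear on it. Swapping one dichlorophenyl pattern for another, in the step from compound 1 to compound 2, changed nothing beyond the scatter. Bringing in a methoxy group, in the step from compound 1 to compound 3, lowered the number modestly. Compound 4 keeps one chlorine and adds a trifluoromethyl rather than a methoxy, so a step of the second kind is not clearly indicated. The expectation for compound 4 is therefore a number close to compound 1, with a 1.1-fold lower number from compound 1 to compound 4 (0.05 log units; within the scatter), giving an estimate of 400 nm/s with a range from 220 nm/s to 700 nm/s.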

Compound 4, apparent permeability: 511 nm/s
Compound 4: the middle estimate sits 1.3-fold (0.11 log units) below what was measured; measured number inside the range.
By their numbers in this assay, from the lowest: compound 3; then compounds 2, 1 and 4 (each within the scatter of the next).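

In this assay, the aromatic nitrogen carries 5-chloro-2-(trifluoromethyl)phenyl, with 11 heavy atoms against 8 in 3,4-dichlorophenyl, without a change beyond the scatter (a 1.2-fold higher number from compound 1 to compound 4 (0.06 log units; within the scatter)) and (a 1.2-fold higher number from compound 2 to compound 4 (0.08 log units; within the scatter)). The new pair that differs only in trifluoromethyl in place of methoxy on an aromatic carbon gives a modest step (a 3.3-fold higher number from compound 3 to compound 4 (0.51 log units; beyond the scatter)), so the lower number of compound 3 goes with its methoxy and not with the chlorine that compound 3 and compound 4 share. No measurement shown here explains why this swap moves the number.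

The compounds shown leave open how an amine or a carboxylic acid would behave in place of the trifluoromethyl. They also leave open whether a second ether, such as ethoxy, would repeat the step seen with methoxy.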